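The compounds below may be only part of what the source reports. "The series", "measured", "known", "first", "only" and "open" are said of these compounds alone.

The shared core is seen in compound 1 `COc1cc(C(=O)c2sc(-c3ccc(Br)cc3)cc2N)cc(OC)c1OC`. Among the compounds with values here, in a functional assay on CCRF-CEM cells (Homo sapiens) for antiproliferative activity (on this read-out higher numbers stand for weaker inhibition and lower numbers for stronger inhibition), compound 1 gives 86 nM, the highest of the three numbers measured so far. Compound 2 `COc1cc(C(=O)c2sc(-c3ccccc3)cc2N)cc(OC)c1OC` gives 4.5 nM, and compound 3 `COc1cc(C(=O)c2sc(-c3ccc(C)cc3)cc2N)cc(OC)c1OC` gives 15 nM. Both replacements of the bromo group lowered the number: a 19-fold lower number from compound 1 to compound 2 (1.28 log units; beyond the scatter) and a 5.7-fold lower number from compound 1 to compound 3 (0.76 log units; beyond the scatter); between the two replacements themselves, a 3.3-fold higher number from compound 2 to compound 3 (0.52 log units; beyond the scatter). Compound 4 `CCOc1ccc(-c2cc(N)c(C(=O)c3cc(OC)c(OC)c(OC)c3)s2)cc1` differs from compound 1 as follows: ethoxy in place of bromo on an aromatic carbon. Within the data shown here, no ethoxy analogue has been measured, so the size of this step rests only on the two bromo replacements already seen, each of which lowered the number, the hydrogen replacement by more than the methyl one. On that basis a lower number is expected for compound 4, of a size nearer the methyl step than the hydrogen step. The step expected is a 3.4-fold lower number from compound 1 to compound 4 (0.54 log units; beyond the scatter). For compound 4 the estimate in this assay is 25 nM, with a range from 8 nM to 80 nM.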

Compound 4, half-maximal inhibitory concentration: 270 nM
Compound 4: middle estimate off by 11-fold (1.03 log units), on the low side, outside the stated range (above it).
By their numbers in this assay, from the lowest: compound 2; then compound 3; then compound 1; then compound 4.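

In this assay, hydrogen and methyl in place of bromo both lowered the number, whereas ethoxy raises it, with a 3.1-fold higher number from compound 1 to compound 4 (0.50 log units; beyond the scatter), so replacing bromo at this position does not lower the number in every case. The gaps to the two smaller substituents are wider, with an 18-fold higher number from compound 3 to compound 4 (1.26 log units; beyond the scatter) and a 60-fold higher number from compound 2 to compound 4 (1.78 log units; beyond the scatter), which places compound 4 as the weakest of the four and gives the order compound 2, compound 3, compound 1, compound 4, with every step beyond the scatter. Nothing available here accounts for this order of the four groups.

The compounds shown leave open whether the higher number of compound 4 goes with the ether oxygen or with the length of the chain. Methoxy and the longer propoxy at the same place would separate the two, while an amine would show how a different oxygen-free group behaves there.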